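Adding a sulfonyl group to compound 3

The compounds below may be only part of what the source reports. "The series", "measured", "known", "first", "only" and "open" are said of these compounds alone.

In a functional assay on QGY-7703 cells (Homo sapiens) for cytotoxicity, read by MTT assay, with a stated time of 24 h (on this read-out lower numbers stand for stronger inhibition and higher numbers for weaker inhibition), compound 1 `CN1C/C(=C\c2ccncc2)C(=O)/C(=C/c2ccccc2C(F)(F)F)C1` gives 4500 nM and compound 3 `O=C1/C(=C/c2ccncc2)CNC/C1=C\c1ccccc1C(F)(F)F` gives 4900 nM. These two values are close, as a 1.1-fold higher number from compound 1 to compound 3 (0.04 log units; within the scatter) shows. Compound 2 `Cc1ccc(S(=O)(=O)N2C/C(=C\c3ccncc3)C(=O)/C(=C/c3ccccc3F)C2)cc1` reports only a limit, > 20000 nM. Compound 4 `Cc1ccc(S(=O)(=O)N2C/C(=C\c3ccncc3)C(=O)/C(=C/c3ccccc3C(F)(F)F)C2)cc1` is built from compound 3 by one change: (4-methylphenyl)sulfonyl in place of hydrogen on an amine nitrogen in a ring. The measured step on this nitrogen involves only methyl and hydrogen, so it says little about so large a group. Compound 2 carries the same (4-methylphenyl)sulfonyl on that nitrogen, though its core differs elsewhere, and its limit of > 20000 nM points towards weaker inhibition. The expected change is a 2.0-fold higher number from compound 3 to compound 4 (0.31 log units; beyond the scatter). For compound 4 the estimated value is 10000 nM, with an expected range of 3000 nM to 20000 nM.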

Compound 4, half-maximal inhibitory concentration: 5090 nM
Compound 4: the middle estimate sits 2.0-fold (0.29 log units) above what was measured, and the stated range covers the measured number.
By their numbers in this assay, from the lowest: compounds 1, 3 and 4 (each within the scatter of the next). At a limit, above all of these: compound 2.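

In this assay, (4-methylphenyl)sulfonyl on the amine nitrogen in the ring fits as well as the smaller groups, with a 1.0-fold higher number from compound 3 to compound 4 (0.02 log units; within the scatter) and a 1.1-fold higher number from compound 1 to compound 4 (0.05 log units; within the scatter). With that sulfonyl group held constant, trifluoromethyl in place of fluoro on an aromatic carbon gives an at least 3.9-fold lower number from compound 2 to compound 4 (0.59 log units; beyond the scatter). This step can only be read as a minimum, since compound 2 gives only a limit: the limit of > 20000 nM in this assay, at which 1 of the 4 values shown sits.

The compounds shown leave open whether a carboxylic acid or a longer chain ending in an amine on this nitrogen would also stay within the scatter.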